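The compounds below may be only part of what the source reports. "The series", "measured", "known", "first", "only" and "open" are said of these compounds alone.

Measured so far:
- compound 1, `CCCCC(=O)N(Cc1ccc(OC)c(O)c1)c1cc(OC)c(OC)c(OC)c1`, gives 170 nM
- compound 2, `COc1cc(NCc2ccc(C)cc2)cc(OC)c1OC`, gives > 80000 nM

Both compounds were tested in a functional assay on HCT-116 cells (Homo sapiens) for inhibition, read by MTT assay, with a stated time of 48 h; a lower number here means a stronger inhibitor, a higher number a weaker inhibitor. Compound 1 is the only one of the two with a real number: in this assay compound 1 gives 170 nM. Among the measured compounds shown here, for compound 2 the assay gives only a limit, > 80000 nM, which says no more than that its value lies beyond what the test could resolve; this limit, (the limit of > 80000 nM in this assay, at which 1 of the 2 values shown sits), is the other value shown, so there is no measured step to compare against.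

Compound 3, `COc1ccc(CN(C(=O)C2CC2)c2cc(OC)c(OC)c(OC)c2)cc1O`, is still to be measured. It differs from compound 1 in one place: cyclopropyl in place of butyl on a carbonyl carbon. The amide and the two aromatic parts of compound 1 are kept. Without a measured pair that shares this change, the size of the step is an open guess; in this assay a change of this kind is expected to be small, at most a modest weakening beyond the scatter. The step from compound 1 to compound 3 is estimated at a 1.8-fold higher number from compound 1 to compound 3 (0.25 log units; within the scatter). Compound 3 is therefore expected to give about 300 nM, in a range from 80 nM to 1200 nM.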

Compound 3, half-maximal inhibitory concentration: 49 nM
Compound 3: the middle estimate sits 6.1-fold (0.79 log units) above what was measured; measured number outside the range, below it.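

In this assay, the group on the carbonyl carbon of the amide proves to be a place where a small change can be read: cyclopropyl in place of butyl gives a 3.5-fold lower number from compound 1 to compound 3 (0.54 log units; beyond the scatter). The open butyl chain is therefore not needed for activity in this pair, and a small ring made only of carbon, with no hydrogen-bond donors or acceptors on either side of the change, does better while the amide and both aromatic parts stay the same. Nothing measured here bears on why this swap lowers the number.

One pair cannot separate the effect of having a ring from the effect of having fewer carbon atoms: a propyl chain on the same carbonyl carbon would speak to that, while a cyclobutyl ring or an amine on a short chain would show how much else this place accepts. As far as these compounds go, whether the same swap gives a similar step when other parts of the core of compound 1 change also stays open.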